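Changing the amino side chain on a shared core

The source may hold more compounds than are shown below. What is called first, only, known or untested is meant among the compounds shown, and "the series" means these compounds.

- Compound 1 `CC(C)(C)CCNc1ncnc2c1ncn2[C@@H]1O[C@H](COS(N)(=O)=O)[C@@H](O)[C@H]1O`: 929 nM
- Compound 2 `COCCNc1ncnc2c1ncn2[C@@H]1O[C@H](COS(N)(=O)=O)[C@@H](O)[C@H]1O`: > 1000 nM (a limit)

Both compounds were tested in a functional assay on K562 cells (Homo sapiens) for antiproliferative activity, read by CellTiter-Glo, with a stated time of 72 h; on this read-out lower numbers stand for an effect already at smaller amounts and higher numbers for an effect only at larger amounts of compound. Compound 2 stands only at a limit, not at a number: the limit of > 1000 nM in this assay, at which 1 of the 2 values shown sits. Compound 3 `CN(Cc1ccco1)c1ncnc2c1ncn2[C@@H]1O[C@H](COS(N)(=O)=O)[C@@H](O)[C@H]1O` carries a different group on the same aromatic carbon: ((furan-2-yl)methyl)(methyl)amino in place of (2-methoxyethyl)amino on an aromatic carbon. Among the compounds with values here, the only measured step that bears on this change is an at least 1.0-fold higher number from compound 1 to compound 2 (0.03 log units; that floor lies within the scatter), which alters the same side chain. On that basis, no step beyond the scatter is expected, and the expected step is a step that the limit leaves unreadable from compound 2 to compound 3. For compound 3 the estimated value is 1200 nM, with an expected range from 400 nM to 5000 nM.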

Compound 3, half-maximal effective concentration: > 1000 nM
Compound 3 gave a limit, no number (the forecaster's own chance of this, stated with the estimate: 60%); the middle value does not contradict the limit.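

In this assay compound 3 gives > 1000 nM, a limit and not a number. On this aromatic carbon, a side chain with a five-membered aromatic ring and no hydrogen-bond donor therefore gives an at least 1.0-fold higher number from compound 1 to compound 3 (0.03 log units; that floor lies within the scatter), while the step between the two limits cannot be read. Comparison at this position now rests mostly on a limit: the limit of > 1000 nM in this assay, at which 2 of the 3 values shown sit.

The compounds shown leave open whether the ring or the methyl on the nitrogen matters more. On these data alone, how a (furan-2-yl)methylamino or benzylamino group would read also stays open.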